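A new group on the oxygen of compound 2

A few compounds are considered here, and "the series" means these few. Any claim that something is new, unique, unknown or untested is made for them only; others in the source may bear on it.

In an ADME assay on microsomes from liver (Homo sapiens) for metabolic stability (a lower number here means slower removal, a higher number faster removal of the compound), compound 1 (`CCn1cnc2c(-c3ccc(F)c(-c4cccnc4)c3)cnnc21`) gives 78 mL.min-1.g-1 and compound 2 (`CCn1cnc2c(-c3ccc(F)c(OCc4ccccn4)c3)cnnc21`) gives 41 mL.min-1.g-1, so these two cannot be told apart. Compound 3 (`CCn1cnc2c(-c3ccc(F)c(Oc4ccc(C#N)cn4)c3)cnnc21`) differs from compound 2 as follows: 5-cyanopyridin-2-yl in place of (pyridin-2-yl)methyl on an oxygen on an aromatic ring. Going by the values given here, the only measured step, a 1.9-fold lower number from compound 1 to compound 2 (0.28 log units; within the scatter), also swaps one group holding a six-membered aromatic ring for another. That single step is thin evidence, and it suggests no shift beyond the scatter in this assay. The expected step is a 1.1-fold lower number from compound 2 to compound 3 (0.03 log units; within the scatter). For compound 3 the estimated value is 38 mL.min-1.g-1, with an expected range of 16 mL.min-1.g-1 to 85 mL.min-1.g-1.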

Compound 3, intrinsic clearance in microsomes: 65 mL.min-1.g-1
Estimate against measurement, compound 3: 1.7-fold (0.23 log units) below, within the range that was stated.
By their numbers in this assay, from the lowest: compounds 2, 3 and 1 (each within the scatter of the next).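

In this assay, the step to 5-cyanopyridin-2-yl on the oxygen, a 1.6-fold higher number from compound 2 to compound 3 (0.20 log units; within the scatter), shows that a nitrile-bearing ring can take the place of (pyridin-2-yl)methyl here without a change that can be told from the scatter. Setting (5-cyanopyridin-2-yl)oxy in place of pyridin-3-yl gives a 1.2-fold lower number from compound 1 to compound 3 (0.08 log units; within the scatter), so all three groups remain indistinguishable at this position. Nothing measured here offers a reason for these numbers. On these data alone, whether a longer chain or an amine on that oxygen would give a step beyond the scatter stays open.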